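The compounds below may be only part of what the source reports. "The series", "measured", "known", "first", "only" and "open" are said of these compounds alone.

Measured so far in an ADME assay on PBMC cells (Homo sapiens) for cytotoxicity, read by trypan blue exclusion, with a stated time of 6 days; a higher number here means that more compound is tolerated, a lower number that less compound is tolerated:

Compound 1 `C[C@@]1(O)[C@H](O)[C@@H](CO)O[C@H]1n1cnc2c(NO)nc(N)nc21` — > 100000 nM, a limit of the assay
Compound 2 `C[C@@]1(O)[C@H](O)[C@@H](CO)O[C@H]1n1cnc2c(N)nc(N=[N+]=[N-])nc21` — > 100000 nM, a limit of the assay
Compound 3 `C[C@@]1(O)[C@H](O)[C@@H](CO)O[C@H]1n1cnc2c(N)nc(ONC(=O)OCc3ccccc3)nc21` — > 100000 nM, a limit of the assay

Compound 2 stands on a limit of this assay, not on a number: in this assay compound 2 reaches > 100000 nM without a measurable half-maximal cytotoxic concentration. It shares this position with the other two compounds, and the shared position is described by the limit of > 100000 nM in this assay, at which 3 of the 3 values shown sit. Among the compounds with values here, no step between measured compounds can be stated on this series, so the direction and size of any change rest on the structural difference alone.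

Compound 4 `COc1nc(N)c2ncn([C@@H]3O[C@H](CO)[C@@H](O)[C@@]3(C)O)c2n1` differs from compound 2 by methoxy in place of azido on an aromatic carbon. Given that compound 2 sits at > 100000 nM, no step beyond the scatter is expected in this assay, and the most likely outcome is again a limit. The expected step is a step that the limit leaves unreadable from compound 2 to compound 4, an estimate rather than a measurement. For compound 4 the estimated half-maximal cytotoxic concentration in this assay is 150000 nM, with a range from 50000 nM to 500000 nM.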

Compound 4, half-maximal cytotoxic concentration: > 100000 nM
Compound 4: only a limit was reported; the forecaster's own chance of this, stated with the estimate: 85%; the middle value lies beyond the limit too.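

No step can be read between compound 2 and compound 4, since neither gives a number, only a limit: the limit of > 100000 nM in this assay, at which 4 of the 4 values shown sit.

The compounds shown leave open at what concentration any of them becomes cytotoxic in this assay and whether methoxy in place of azido on an aromatic carbon changes that concentration.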